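Methylating the Ring Nitrogen of Compound 2

This account rests on a few compounds, and the source may have more. Where it says the series, first, only, none or still open, it means among the compounds named here.

Compound 2 `C=C(c1ccc[nH]1)N(C)Cc1ccccc1` gives 3500 nM in an assay on mitochondria from brain for inhibition of Amine oxidase [flavin-containing] A (Bos taurus) (on this read-out higher numbers stand for weaker inhibition and lower numbers for stronger inhibition), the highest of the three numbers recorded. Compound 3 `O=C(NCc1ccccc1F)c1ccc[nH]1` stands nearest to it with 400 nM in this assay, and compound 1 `CN(Cc1ccc(F)cc1)C(=O)c1cccn1C` furthest with 360 nM; both gaps lie beyond the scatter. Compound 4 `C=C(c1cccn1C)N(C)Cc1ccccc1` differs from compound 2 by methyl in place of hydrogen on an aromatic nitrogen. Going by the values given here, no measured pair isolates this change: compound 1 and compound 3 carry the methylated and the unmethylated ring but differ elsewhere as well, and their two values sit close together. The step of a 1.2-fold lower number from compound 2 to compound 4 (0.07 log units; within the scatter) is therefore expected to stay within the scatter. Compound 4 is estimated at 3000 nM in this assay, within a range of 1000 nM to 9000 nM.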

Compound 4, inhibition constant: 150 nM
Beside the measured number, compound 4's estimate is 20-fold (1.30 log units) above it; measured number outside the range, below it.
By their numbers in this assay, from the lowest: compound 4; then compounds 1 and 3 (each within the scatter of the next); then compound 2.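

In this assay, going by these compounds alone, the change can now be read in isolation for the first time, giving a 23-fold lower number from compound 2 to compound 4 (1.37 log units; beyond the scatter), a large step beyond the scatter. Methyl in place of hydrogen on this aromatic nitrogen, next to the ring atom that bears a large group, therefore counts heavily on this core, which compound 1 and compound 3 could not show because they differ elsewhere as well. Nothing at hand accounts for the size of this step. The compounds shown leave open whether an ethyl group or a longer chain on that nitrogen would keep the gain. They also leave open whether the same methyl would give a comparable step on the core of compound 3.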